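A Methyl Group Shifts on the Phenyl Ring

The source may hold more compounds than are shown below. What is called first, only, known or untested is meant among the compounds shown, and "the series" means these compounds.

In a physicochemical assay for permeability, using PAMPA (a lower number here means that the compound crosses the layer more slowly, a higher number that the compound crosses the layer faster), compound 1 `COc1cccc(Br)c1-c1nc(CN2CCC(C(=O)NCCCN3C[C@H](C)C[C@H](C)C3)CC2)c(C)o1` gives 245 10^-6 cm/s and compound 2 `Cc1cccc(C)c1-c1nc(CN2CCC(C(=O)NCCCN3C[C@H](C)C[C@H](C)C3)CC2)c(C)o1` gives 254 10^-6 cm/s, so the two lie within the scatter of each other. Compound 3 `Cc1ccc(-c2nc(CN3CCC(C(=O)NCCCN4C[C@H](C)C[C@H](C)C4)CC3)c(C)o2)c(C)c1` differs from compound 2 by 2,4-dimethylphenyl in place of 2,6-dimethylphenyl on an aromatic carbon. Going by the values given here, the one measured step, a 1.0-fold higher number from compound 1 to compound 2 (0.02 log units; within the scatter), exchanged the group at this same place and stayed within the scatter. Among the compounds with values here, no measured step shows a methyl group changing place, so this evidence is only indirect. The expected step, none beyond the scatter, is a 1.1-fold lower number from compound 2 to compound 3 (0.02 log units; within the scatter). The estimate for compound 3 is 240 10^-6 cm/s, with an expected range of 130 10^-6 cm/s to 420 10^-6 cm/s.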

Compound 3, apparent permeability: 353 10^-6 cm/s
Compound 3: middle estimate off by 1.5-fold (0.17 log units), on the low side, and the stated range covers the measured number.
By their numbers in this assay, from the lowest: compounds 1, 2 and 3 (each within the scatter of the next).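

In this assay the exchange of 2,6-dimethylphenyl for 2,4-dimethylphenyl gives a 1.4-fold higher number from compound 2 to compound 3 (0.14 log units; within the scatter) and so shows that rearranging the same atoms at this position stays within the scatter. Set against 2-bromo-6-methoxyphenyl, the same group gives a 1.4-fold higher number from compound 1 to compound 3 (0.16 log units; within the scatter) and all three groups at this position therefore read alike so far. No measured evidence accounts for these numbers.

The compounds shown leave open whether a carboxylic acid or an amine on this phenyl ring would also stay within the scatter.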